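Ethyl in place of phenyl in compound 2

A few compounds are considered here, and "the series" means these few. Any claim that something is new, unique, unknown or untested is made for them only; others in the source may bear on it.

Of the compounds shown here, three on a shared core have been measured in an ADME assay on SH-SY5Y cells (Homo sapiens) for cytotoxicity, read by MTT assay, with a stated time of 48 h; a higher number here means a weaker inhibitor, a lower number a stronger inhibitor. Compound 1 (`COc1ccc(C(=O)/C=C/c2ccc(C(=O)O)cc2)c(O)c1`) gives > 100000 nM, which is a limit of the assay and not a number. Compound 3 (`COc1ccc(C(=O)/C=C/c2ccc(C(=O)N3CCCCC3)cc2)c(O)c1`) gives > 100000 nM, again a limit. Compound 2 (`COc1ccc(C(=O)/C=C/c2ccc(OCCCOc3ccccc3)c(OC)c2)c(O)c1`) gives > 100000 nM, likewise a limit. Compound 2 therefore has no readable rank among the three, and the set as a whole comes down to the limit of > 100000 nM in this assay, at which 3 of the 3 values shown sit.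

The compound still to be measured, compound 4 (`CCOCCCOc1ccc(/C=C/C(=O)c2ccc(OC)cc2O)cc1OC`), differs from compound 2 at one place: ethyl in place of phenyl on an oxygen on a saturated carbon. Put simply, the phenoxy of compound 2 becomes ethoxy in compound 4. For the measured compounds named here, the only measured step is a step that the two limits leave unreadable from compound 1 to compound 3, made at another place in the structure, and it offers no size to carry over. With compound 2 at > 100000 nM, no step beyond the usual scatter is expected in either direction, and compound 4 is expected to stay at the same limit. The expected size of a number no higher from compound 2 to compound 4 (the limit leaves the size open) is accordingly small. The estimate for compound 4 is 100000 nM, with a range from 50000 nM to 200000 nM.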

Compound 4, half-maximal inhibitory concentration: > 100000 nM
Compound 4 ended at the assay's limit; the forecaster's own chance of this, stated with the estimate: 75%; the middle value sits exactly at the limit.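

In this assay compound 4 gives > 100000 nM, which is a limit of the assay and not a number. Compound 2 also stands at a limit, so no step can be read between compound 2 and compound 4. The compounds shown leave open whether any change on the shared core alters the read-out at all: the limit of > 100000 nM in this assay, at which 4 of the 4 values shown sit.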